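Removing Bromo from Two Related Cores

The source may hold more compounds than are shown below. What is called first, only, known or untested is meant among the compounds shown, and "the series" means these compounds.

Measured compounds:
Compound 1, `Cc1ccc2nc(/N=C3\C(=O)N(CN(c4ccccc4)c4ccccc4)c4cccc(Br)c43)sc2c1`: 75100 nM
Compound 2, `CN(C)CN1C(=O)C(=O)c2c(Br)cccc21`: 93700 nM
Compound 3, `Cc1ccc2nc(/N=C3\C(=O)N(CN(c4ccccc4)c4ccccc4)c4ccccc43)sc2c1`: 34100 nM

All three were tested in a functional assay on MDA-MB-231 cells (Homo sapiens) for cytotoxicity, read by sulforhodamine B assay, with a stated time of 48 h; on this read-out lower numbers stand for stronger inhibition of growth and higher numbers for weaker inhibition of growth. Compound 3 differs from compound 1 by hydrogen in place of bromo on an aromatic carbon, and that change gave a 2.2-fold lower number from compound 1 to compound 3 (0.34 log units; beyond the scatter). Compound 2 carries a smaller core; how its core differs from the core of compound 1 is not broken down here. Its value sits close to that of compound 1, while compound 3 gives a lower number than either.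

Compound 4, `CN(C)CN1C(=O)C(=O)c2ccccc21`, is not yet measured. It differs from compound 2 by hydrogen in place of bromo on an aromatic carbon, the same change that separates compound 1 from compound 3, at the same place. Because the step of a 2.2-fold lower number from compound 1 to compound 3 (0.34 log units; beyond the scatter) was modest, compound 4 is expected to show a step of similar size, a 2.1-fold lower number from compound 2 to compound 4 (0.32 log units; beyond the scatter). For compound 4 the expected value in this assay is 45000 nM, with a likely range from 20000 nM to 120000 nM.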

Compound 4, concentration for 50% growth inhibition: 65600 nM
The estimate for compound 4 lay 1.5-fold (0.16 log units) below the measured number; the measured number falls inside the stated range.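

In this assay, hydrogen in place of bromo on the core of compound 2 gave a 1.4-fold lower number from compound 2 to compound 4 (0.15 log units; within the scatter), a step too small to separate from the usual spread of repeated measurements. Set beside the step on the core of compound 1, this step does not differ from it by more than such pairs of steps normally scatter: the same change on two cores in this assay, a 2.2-fold lower number (0.34 log units; beyond the scatter) from compound 1 to compound 3 and a 1.4-fold lower number (0.15 log units; within the scatter) from compound 2 to compound 4, 1.5-fold (0.19 log units) apart, within the scatter of two such steps. So the change carried over from one core to the other with no detectable difference in size, but this does not prove that the two steps are equal, and two cores cannot speak for the whole series.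

On these data alone, only bromo and hydrogen appear at this place, so the effect of a fluoro group, a methoxy group or an amine there remains open. Also open, as far as these compounds go, is whether the step would hold on a third core.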